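The source may hold more compounds than are shown below. What is called first, only, known or untested is meant among the compounds shown, and "the series" means these compounds.

Series notes. Compound 1 `CCOC(=O)c1c(-c2ccc(Cl)cc2)cc(-c2ccccc2)nc1N1CCCCC1` carries piperidin-1-yl on an aromatic carbon of the shared core, and in a functional assay on the whole organism (strain Wister albino) for inhibition, with Rattus norvegicus as the target, read by paw edema, with stated times of 1 h and 4 h, at a dose of 50 mg/kg by the intraperitoneal route (on this read-out higher numbers stand for more inhibition at the one dose given (going by the name of the read-out) and lower numbers for less inhibition), compound 1 gives 70.1%. Compound 2 `CCOC(=O)c1c(-c2ccc(Cl)cc2)cc(-c2ccccc2)nc1Nc1ccc(C)cc1` has (4-methylphenyl)amino in place of piperidin-1-yl on an aromatic carbon, and in this assay compound 2 gives 61.8%. For the measured compounds named here, the only measured step, a number 8.3 percentage points lower from compound 1 to compound 2 (within the scatter), lies within the scatter. Compound 2 thus holds the smaller of the two numbers shown, but its sole neighbour, compound 1, sits within the scatter of it, so no order between the two is claimed.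

Compound 3 `CCOC(=O)c1c(-c2ccc(Cl)cc2)cc(-c2ccccc2)nc1Nc1ccc(Cl)cc1` is not yet measured. It differs from compound 2 by chloro in place of methyl on an aromatic carbon. Going by the values given here, no measured step bears on this change: the single step on record concerns the exchange of piperidin-1-yl for (4-methylphenyl)amino, a different part of the molecule, and it stays within the scatter. Nothing in the data therefore points to a step in this assay beyond the scatter in either direction, and the expected step is a number 0.2 percentage points higher from compound 2 to compound 3 (within the scatter), essentially flat. Compound 3 is accordingly estimated at 62% in this assay, with an expected range from 50% to 74%.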

Compound 3, a percentage reported as inhibition, in the whole organism at one dose (the size of the read-out at that dose, not a potency): 65.2%
The estimate for compound 3 lay 3.2 percentage points below the measured number, within the range that was stated.
By their numbers in this assay, from the lowest: compounds 2, 3 and 1 (each within the scatter of the next).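

For the compounds shown here, this is the first measured change at the aromatic carbon para to a large group: in this assay, chloro in place of methyl gives a number 3.4 percentage points higher from compound 2 to compound 3 (within the scatter), so exchanging these two single-atom-sized substituents at this position produces no step beyond the scatter. The second replacement of piperidin-1-yl, now by (4-chlorophenyl)amino, gives a number 4.9 percentage points lower from compound 1 to compound 3 (within the scatter), so with chloro as with methyl, this exchange on the shared core also stays within the scatter, and the three compounds cannot be put in order. No measurement at hand offers an explanation of these numbers.

The compounds shown leave open whether a clearly different group at the same position, such as a methoxy group, a dimethylamino group or a carboxylic acid, would move the number beyond the scatter. They also leave open what a morpholin-4-yl group in place of piperidin-1-yl, or an amide or a carboxylic acid in place of the ethyl ester, would do at this dose.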